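From 4-chlorophenyl to 2-methoxyphenyl: expected gain

The source may report more compounds than this note shows. Statements on the series, on what has been measured and on what is new or still open speak of the compounds shown alone.

In a functional assay on Jurkat cells (Homo sapiens) for antiproliferative activity, read by MTT assay, with a stated time of 72 h (a lower number here means a stronger inhibitor, a higher number a weaker inhibitor), compound 1 `COc1cc(-n2ncnc2-c2ccc(Cl)cc2)cc(OC)c1OC` has only a limit, > 10000 nM. Compound 2 `CCOc1ccc(-c2ncnn2-c2cc(OC)c(OC)c(OC)c2)cc1` gives 5 nM. For the measured compounds named here, the one measured step that bears on the change is an at least 2000-fold lower number from compound 1 to compound 2 (3.30 log units; beyond the scatter), a large step with ethoxy in place of chloro on an aromatic carbon. Compound 3 `COc1ccccc1-c1ncnn1-c1cc(OC)c(OC)c(OC)c1` has 2-methoxyphenyl in place of 4-chlorophenyl on an aromatic carbon. It also loses the chloro group, but its new group differs from that of compound 2, so only part of an at least 2000-fold lower number from compound 1 to compound 2 (3.30 log units; beyond the scatter) is expected to carry over. The expected step is an at least 25-fold lower number from compound 1 to compound 3 (1.39 log units; beyond the scatter), towards a lower number in this assay. Compound 3 is estimated at 400 nM, with an expected range of 30 nM to 5000 nM.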

Compound 3, half-maximal inhibitory concentration: > 10000 nM
Compound 3 ended at the assay's limit; the forecaster's own chance of this, stated with the estimate: 20%; middle value at least 25-fold (1.39 log units) away from the limit.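

No step from compound 1 to compound 3 can be read, because both compounds stand at a limit and not at a number: the limit of > 10000 nM in this assay, at which 2 of the 3 values shown sit.

As far as these compounds go, whether 2-methoxyphenyl and 4-chlorophenyl differ at all on the shared core stays open.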